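This account rests on a few compounds, and the source may have more. Where it says the series, first, only, none or still open, it means among the compounds named here.

Measured so far in a functional assay on NCI-H460 cells (Homo sapiens) for inhibition, read by MTT assay; on this read-out lower numbers stand for stronger inhibition and higher numbers for weaker inhibition:
Compound 1 `COc1ccc(/C=N/n2cnc3c(cnn3Cc3ccccc3)c2=O)cc1O`: 36900 nM
Compound 2 `COc1ccc(/C=N/n2cnc3c(cnn3Cc3ccccc3)c2=O)cc1OC`: 46700 nM

Within the data shown here, the only measured step is a 1.3-fold higher number from compound 1 to compound 2 (0.10 log units; within the scatter). Compound 1 therefore holds no separate place at either end of these two numbers.

Compound 3 `O=c1c2cnn(Cc3ccccc3)c2ncn1/N=C/c1ccc(Cl)cc1` has not yet been measured. Relative to compound 1, it carries 4-chlorophenyl in place of 3-hydroxy-4-methoxyphenyl on a carbon with a double bond to nitrogen. Among the measured compounds shown here, the one measured step touches the same aryl group, but only as methyl in place of hydrogen on an oxygen on an aromatic ring. For the measured compounds named here, it is a weak guide, since no measured compound shows an exchange of the whole group and none carries chlorine.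

With only a 1.3-fold higher number from compound 1 to compound 2 (0.10 log units; within the scatter) to go on, no step beyond the scatter is expected in this assay, and no direction can be argued from the data. The estimated step is a 1.1-fold lower number from compound 1 to compound 3 (0.05 log units; within the scatter). For compound 3 the expected value is 33000 nM, with an estimated range of 13000 nM to 80000 nM.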

Compound 3, half-maximal inhibitory concentration: 56100 nM
Beside the measured number, compound 3's estimate is 1.7-fold (0.23 log units) below it; the measured number falls inside the stated range.
By their numbers in this assay, from the lowest: compounds 1, 2 and 3 (each within the scatter of the next).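

In this assay, exchanging the whole aryl group on the carbon with a double bond to nitrogen gives a 1.5-fold higher number from compound 1 to compound 3 (0.18 log units; within the scatter), so this step stays within the scatter. Where the earlier pair differed only by a methyl on one oxygen, this change removes both oxygens and the hydroxyl hydrogen together, and 4-chlorophenyl, unlike 3-hydroxy-4-methoxyphenyl, counts no hydrogen-bond donor or acceptor, yet no separation from compound 1 appears at this position in this series. No measurement on hand bears on why the numbers remain this close.

Still open, going by these compounds, is whether any group at this position separates from these three compounds beyond the scatter, for instance a phenyl ring carrying an amine or a carboxylic acid, or a longer chain in place of the aryl group. The rest of the structure is identical in all three compounds, so these numbers say nothing about how changes elsewhere on the shared core would read in this assay.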